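Replacing a Cyclic Urea with an Open Urea

This account rests on a few compounds, and the source may have more. Where it says the series, first, only, none or still open, it means among the compounds named here.

Of the compounds shown here, three have been tested in a functional assay on HT-1080 cells (Homo sapiens) for inhibition, read by sulforhodamine B assay, with a stated time of 48 h (a higher number here means a weaker inhibitor, a lower number a stronger inhibitor), and a fourth is awaiting measurement. Compound 3 `O=C1NCCN1c1ccc(/C=C\c2cccc(Cl)c2)cc1` gives 35 nM. Compound 1 `CCNC(=O)Nc1ccc(/C=C\c2cccc(Cl)c2)cc1` differs from it in one place: (ethylcarbamoyl)amino in place of 2-oxoimidazolidin-1-yl on an aromatic carbon. In this assay compound 1 gives 31000 nM. That single exchange produced a large loss of potency, an 890-fold higher number from compound 3 to compound 1 (2.95 log units; beyond the scatter).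

Compound 2 `Cc1cc(C)cc(/C=C/c2ccc(N3CCNC3=O)cc2)c1` is built on another core; how its core differs from that of compound 3 is not broken down here. For compound 2 this assay reports only a limit, > 20000 nM, and not a number; this is the limit of > 20000 nM in this assay, at which 1 of the 3 values shown sits.

Compound 4 `CCNC(=O)Nc1ccc(/C=C/c2cc(C)cc(C)c2)cc1` has not been measured yet. It differs from compound 2 by the same kind of change that separates compound 3 from compound 1: (ethylcarbamoyl)amino in place of 2-oxoimidazolidin-1-yl on an aromatic carbon. The surroundings are described slightly differently, the place being para to a large group in compound 2 and para to a group of 9 heavy atoms in compound 3, so the change is of the same kind rather than the same. Since compound 2 already sits at the limit of the assay, and since the measured step was an 890-fold higher number from compound 3 to compound 1 (2.95 log units; beyond the scatter), the expected step is a step that the limit leaves unreadable from compound 2 to compound 4, meaning inhibition is expected to fall further or stay beyond reach of the assay. Compound 4 is therefore estimated at 200000 nM, with a likely span from 20000 nM to 2000000 nM, and a strong chance that only a limit is reported.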

Compound 4, half-maximal inhibitory concentration: > 20000 nM
Compound 4: no number, only a limit (the forecaster's own chance of this, stated with the estimate: 90%); the middle value is on the limit's open side.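

Compound 4 gives only a limit in this assay, not a number, and compound 2 does as well, so the step between them cannot be read: the limit of > 20000 nM in this assay, at which 2 of the 4 values shown sit. The compounds shown leave open whether exchanging 2-oxoimidazolidin-1-yl for (ethylcarbamoyl)amino weakens inhibition on the core of compound 2 as it does on the core of compound 3.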